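Changing the aromatic group of compound 3

This account rests on a few compounds, and the source may have more. Where it says the series, first, only, none or still open, it means among the compounds named here.

compound 1 `CC1(C)Oc2ccc(C#N)cc2[C@@H](/N=C(\NC#N)Nc2ccc(N)cc2)[C@@H]1O` gives 3500 nM
compound 2 `CC1(C)Oc2ccc(C#N)cc2[C@@H](/N=C(\NC#N)Nc2ccc(C(F)(F)F)cc2)[C@@H]1O` gives 8100 nM
compound 3 `COC(=O)c1cccc(N/C(=N/[C@@H]2c3cc(C#N)ccc3OC(C)(C)[C@H]2O)NC#N)c1` gives 4100 nM

All three numbers come from a functional assay (aorta) with Rattus norvegicus as the target (on this read-out higher numbers stand for weaker inhibition and lower numbers for stronger inhibition), and compound 3 stays within the scatter of both other compounds, with a 1.2-fold higher number from compound 1 to compound 3 (0.07 log units; within the scatter) and a 2.0-fold lower number from compound 2 to compound 3 (0.30 log units; within the scatter) as its two links. Compound 4 `COc1ccc(N/C(=N/[C@@H]2c3cc(C#N)ccc3OC(C)(C)[C@H]2O)NC#N)cc1` has not been measured yet. It carries 4-methoxyphenyl in place of 3-(methoxycarbonyl)phenyl on an amine nitrogen. The two steps that reach compound 3 swap the aromatic group at this same place, and neither moves the number beyond the scatter. The largest step among the three compounds (a 2.3-fold higher number from compound 1 to compound 2 (0.36 log units; beyond the scatter)) is only modest. Within the data shown here, no measured compound carries 4-methoxyphenyl, so the direction stays open, and no step beyond the scatter is expected in this assay here. The step expected for compound 4 is a 1.1-fold higher number from compound 3 to compound 4 (0.04 log units; within the scatter) and it rests on these small steps. Compound 4 is estimated at 4500 nM (expected range 2000 nM to 10000 nM).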

Compound 4, half-maximal inhibitory concentration: 32500 nM
Compound 4: middle estimate off by 7.2-fold (0.86 log units), on the low side, and the stated range ends below it.
By their numbers in this assay, from the lowest: compounds 1, 3 and 2 (each within the scatter of the next, the first and the last beyond it); then compound 4.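

The aromatic group on this amine nitrogen matters more in this assay than compounds 1 to 3 showed: replacing 3-(methoxycarbonyl)phenyl with 4-methoxyphenyl gives a 7.9-fold higher number from compound 3 to compound 4 (0.90 log units; beyond the scatter). Methoxy also stands apart from the other two groups on the aromatic carbon, with a 4.0-fold higher number from compound 2 to compound 4 (0.60 log units; beyond the scatter) and a 9.3-fold higher number from compound 1 to compound 4 (0.97 log units; beyond the scatter), so compound 4 is the weakest of the four, with its steps to all the others beyond the scatter. Nothing available explains this loss of inhibition.

The names 3-(methoxycarbonyl)phenyl and 4-methoxyphenyl differ in both the group and the number in the name, so these compounds cannot separate those two changes. Nor do they show whether a plain phenyl group, or hydroxy or ethoxy in place of methoxy, would give a similarly high number.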